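From 2-methoxyphenyl to 4-methylphenyl on a shared core

The source may report more compounds than this note shows. Statements on the series, on what has been measured and on what is new or still open speak of the compounds shown alone.

compound 1 `O=C1C(Nc2ccccc2F)=CC(=O)c2c1nc1n2[C@H]2OC[C@@H](O)[C@H]2OC1`: 2000 nM
compound 2 `CCc1ccc(NC2=CC(=O)c3c(nc4n3[C@H]3OC[C@@H](O)[C@H]3OC4)C2=O)cc1`: 1110 nM
compound 3 `COc1ccccc1NC1=CC(=O)c2nc3n(c2C1=O)[C@H]1OC[C@@H](O)[C@H]1OC3`: 1630 nM

These three values come from a functional assay on MGC-803 cells (Homo sapiens) for inhibition, read by sulforhodamine B assay (on this read-out higher numbers stand for weaker inhibition and lower numbers for stronger inhibition), and lie close together. Compound 3 stands within the scatter of both compound 1 and compound 2, so the numbers give no order among them.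

Compound 4 `Cc1ccc(NC2=CC(=O)c3nc4n(c3C2=O)[C@H]2OC[C@@H](O)[C@H]2OC4)cc1` has not yet been measured. Its structure differs from that of compound 3 by 4-methylphenyl in place of 2-methoxyphenyl on an amine nitrogen, which puts 4-methylphenyl in place of 2-methoxyphenyl on an amine nitrogen. Going by the values given here, one measured step bears on this change: a 1.8-fold lower number from compound 1 to compound 2 (0.26 log units; within the scatter), with 4-ethylphenyl in place of 2-fluorophenyl on an amine nitrogen. Among the compounds with values here, that exchange stayed within the scatter, although no measured compound carries 4-methylphenyl itself.

In this assay the expected result is therefore no shift beyond the scatter, and the estimated step is a 1.3-fold lower number from compound 3 to compound 4 (0.10 log units; within the scatter) for this exchange. For compound 4 the estimated value is 1300 nM, with an expected range from 650 nM to 2600 nM in this assay.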

Compound 4, half-maximal inhibitory concentration: 1420 nM
For compound 4 the middle estimate is 1.1-fold (0.04 log units) below the measured one; the measured number falls inside the stated range.
By their numbers in this assay, from the lowest: compounds 2, 4, 3 and 1 (each within the scatter of the next).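

In this assay, the exchange on the amine nitrogen gives a 1.1-fold lower number from compound 3 to compound 4 (0.06 log units; within the scatter), even though 4-methylphenyl has no hydrogen-bond acceptor and 2-methoxyphenyl has one. Read with the earlier 1.8-fold lower number from compound 1 to compound 2 (0.26 log units; within the scatter), this makes two exchanges of one substituted phenyl group for another at this nitrogen, and neither moves the number beyond the scatter. Nothing available here explains why these exchanges leave the number in place.

Going by these compounds, all four compounds carry a phenyl ring with a single substituent on this nitrogen, so it remains open whether a carboxylic acid on that ring, a longer chain such as butyl, or a cyclohexyl group in place of the ring would shift the number beyond the scatter. The effect of a substituent's identity also remains unseparated from that of its place on the ring, since each compound carries a different group.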